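Terminal nitrogen substitution on a quinoline thiosemicarbazone

This account rests on a few compounds, and the source may have more. Where it says the series, first, only, none or still open, it means among the compounds named here.

Working notes on a small set of thiosemicarbazones read in a functional assay on HT-29 cells (Homo sapiens) for antiproliferative activity, read by sulforhodamine B assay, with a stated time of 72 h; a lower number here means a stronger inhibitor, a higher number a weaker inhibitor. Compound 1 `NC(=S)N/N=C/c1ccc2ccccc2n1` carries an unsubstituted terminal nitrogen on the thiocarbonyl side; in this assay compound 1 gives 100000 nM, the highest number among the two values that were read as numbers. Compound 2 `CN(C)C(=S)N/N=C/c1ccc2cccnc2n1` differs from compound 1 in both the core and the substitution of the terminal nitrogen; in this assay compound 2 gives 410 nM. Compound 3 `NC(=S)N/N=C/c1cnc2ccccc2n1` returns only a limit in this assay: > 100000 nM. That limit is the one at which (the limit of > 100000 nM in this assay, at which 1 of the 3 values shown sits).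

Compound 4 `S=C(N/N=C/c1ccc2ccccc2n1)Nc1ccc(Cl)cc1` has not yet been measured in this assay. It differs from compound 1 by 4-chlorophenyl in place of hydrogen on an amide-type nitrogen. Among the measured compounds shown here, no step between two measured compounds isolates this change, so the expectation rests on the position of compound 1 and on the set as a whole. A step from compound 1 to compound 4 toward a lower number, beyond the scatter, is expected: a 20-fold lower number from compound 1 to compound 4 (1.30 log units; beyond the scatter). For compound 4 the estimate in this assay is 5000 nM, within 500 nM to 50000 nM.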

Compound 4, half-maximal inhibitory concentration: 97200 nM
Beside the measured number, compound 4's estimate is 19-fold (1.29 log units) below it; the measured number lies above the stated range.
By their numbers in this assay, from the lowest: compound 2; then compounds 4 and 1 (each within the scatter of the next).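

On the amide-type nitrogen whose other neighbour is the thiocarbonyl carbon, 4-chlorophenyl in place of hydrogen gives no separation in this assay: a 1.0-fold lower number from compound 1 to compound 4 (0.01 log units; within the scatter). Among the compounds shown here, this is the first step in the set that isolates this position, as compound 2 differs from compound 1 in the core as well as at this nitrogen, so the number of compound 2, 410 nM, cannot be assigned to either difference alone. The one limit in the set belongs to compound 3 and is a limit, not a number: the limit of > 100000 nM in this assay, at which 1 of the 4 values shown sits.

Still open, on these data alone, is whether dimethyl on this nitrogen would lower the number on the core of compound 1. Also open, as far as these compounds go, is how a cyclic amine or a longer alkyl chain at this position would read on either core.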